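Para-substituent swap on a trimethoxyphenyl benzimidazole series

A few compounds are considered here, and "the series" means these few. Any claim that something is new, unique, unknown or untested is made for them only; others in the source may bear on it.

Measured compounds:
compound 1, `COc1cc(-n2cnc3ccc(-c4ccc([N+](=O)[O-])cc4)cc32)cc(OC)c1OC`: 8940 nM
compound 2, `COc1cc(-n2cnc3ccc(-c4cccc(C)c4C)cc32)cc(OC)c1OC`: 9250 nM
compound 3, `COc1cc(-n2cnc3ccc(-c4ccc(Cl)cc4)cc32)cc(OC)c1OC`: a limit, > 10000 nM

In a functional assay on A549 cells (Homo sapiens) for antiproliferative activity, read by MTT assay, with a stated time of 72 h (a lower number here means a stronger inhibitor, a higher number a weaker inhibitor), compound 1 gives 8940 nM, the lower of the two numbers reported; its neighbour compound 2 gives 9250 nM, and the step of a 1.0-fold higher number from compound 1 to compound 2 (0.01 log units; within the scatter) is within the scatter, so no order between them can be claimed. For compound 3 the assay reports only a limit, > 10000 nM, as noted in the limit of > 10000 nM in this assay, at which 1 of the 3 values shown sits. The steps of an at least 1.1-fold higher number from compound 1 to compound 3 (0.04 log units; that floor lies within the scatter) and an at least 1.0-fold higher number from compound 2 to compound 3 (0.03 log units; that floor lies within the scatter) likewise have floors within the scatter.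

Compound 4, `COc1ccc(-c2ccc3ncn(-c4cc(OC)c(OC)c(OC)c4)c3c2)cc1`, differs from compound 1 by methoxy in place of nitro on an aromatic carbon. None of the measured steps covers this exact change, but all three swaps of the pendant aryl group, from nitro to dimethyl to chloro, leave the numbers clustered at the weak end, with no step shown beyond the scatter. The expected step of a 1.1-fold higher number from compound 1 to compound 4 (0.03 log units; within the scatter) is therefore small, if anything toward a higher number. Compound 4 is estimated at 9500 nM, with a range from 4500 nM to 20000 nM.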

Compound 4, half-maximal inhibitory concentration: > 10000 nM
Compound 4 gave a limit, no number (the forecaster's own chance of this, stated with the estimate: 40%); middle value at least 1.0-fold (0.02 log units) away from the limit.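

In this assay compound 4 gives only a limit, so a second para substituent on the pendant phenyl ring now sits at that limit: the limit of > 10000 nM in this assay, at which 2 of the 4 values shown sit. The readable steps are an at least 1.1-fold higher number from compound 1 to compound 4 (0.04 log units; that floor lies within the scatter) and an at least 1.0-fold higher number from compound 2 to compound 4 (0.03 log units; that floor lies within the scatter); neither shows an order, so replacing nitro with methoxy at this position, para to a large group, produced no measurable gain or loss. The step between compound 3 and compound 4 cannot be read, as both values are limits.

From the compounds shown here alone, how far compound 3 and compound 4 lie beyond the limit remains open. So does whether an amine or a carboxylic acid at this same position would give a number clearly apart from those of compound 1 and compound 2.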